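Carrying a Methyl Step from One Core to Another

The compounds below may be only part of what the source reports. "The series", "measured", "known", "first", "only" and "open" are said of these compounds alone.

The measured compounds are compound 1, `CCOc1cc(NC(=O)NCc2cc(C)c(-c3cn(C)nc3C(F)(F)F)nn2)cc(C#N)n1`, compound 2, `Cc1cc(CNC(=O)Nc2cc(OCCO)nc(C(F)(F)F)c2)nnc1-c1cn(C)nc1C(F)(F)F`, and compound 3, `CCOc1nc(C#N)cc(NC(=O)NCc2cc(C)c(-c3cn(C)nc3C(F)(F)F)nn2)c1C`. In a functional assay on CHO cells for antagonist activity at sphingosine 1-phosphate receptor 2 (Homo sapiens), read by fluorescence and calcium flux, with a stated time of 3 min (a lower number here means a stronger inhibitor, a higher number a weaker inhibitor), compound 1 gives 11000 nM, compound 2 gives 348000 nM, and compound 3 gives 7100 nM.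

Compound 3 arises from compound 1 by methyl in place of hydrogen on an aromatic carbon, and this step gave a 1.5-fold lower number from compound 1 to compound 3 (0.19 log units; within the scatter). Compound 2 rests on a different core; the difference between the two cores is not broken down here, and compound 2 stands apart from both other compounds by margins beyond the scatter. The unmeasured compound 4, `Cc1cc(CNC(=O)Nc2cc(C(F)(F)F)nc(OCCO)c2C)nnc1-c1cn(C)nc1C(F)(F)F`, arises from compound 2 by methyl in place of hydrogen on an aromatic carbon. This is the same kind of change as that from compound 1 to compound 3, though the surroundings differ: in compound 4 the methyl sits ortho to a 2-hydroxyethoxy group and para to a trifluoromethyl group, whereas in compound 3 it sits ortho to an ethoxy group and para to a cyano group. Going by the values given here, the one measured instance of this change, from compound 1 to compound 3, gave a 1.5-fold lower number from compound 1 to compound 3 (0.19 log units; within the scatter), within the scatter, and so the step in this assay is expected to be similarly small, a 1.4-fold lower number from compound 2 to compound 4 (0.14 log units; within the scatter). On that basis compound 4 is estimated at 250000 nM, with a likely range from 100000 nM to 700000 nM.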

Compound 4, half-maximal inhibitory concentration: 84000 nM
Compound 4: middle estimate off by 3.0-fold (0.47 log units), on the high side; measured number outside the range, below it.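

On the core of compound 2, methyl in place of hydrogen on an aromatic carbon gave a 4.1-fold lower number from compound 2 to compound 4 (0.62 log units; beyond the scatter) in this assay. Carried from one core to the other, the change did not keep its size: the same change on two cores in this assay, a 1.5-fold lower number (0.19 log units; within the scatter) from compound 1 to compound 3 and a 4.1-fold lower number (0.62 log units; beyond the scatter) from compound 2 to compound 4, 2.7-fold (0.43 log units) apart, beyond the scatter of two such steps. Going by these compounds alone, this shows that the size of the step read on one core cannot simply be transferred to the other, but with only one pair on each core it does not show which of the differences between them accounts for the gap, nor whether the gap would recur in further pairs.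

Within the data shown here, it remains open whether the larger step follows the 2-hydroxyethoxy group or the trifluoromethyl group that surround the methyl in compound 4, which a pair combining only one of these groups with the ethoxy or nitrile of compound 3 could separate. As far as these compounds go, it is also open whether an ethyl group or a chlorine atom on the same aromatic carbon would give steps that differ between the two cores in the same way.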